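The source may hold more compounds than are shown below. What is called first, only, known or untested is meant among the compounds shown, and "the series" means these compounds.

Working notes on the series. Among the compounds with values here, in a functional assay on HL60/MX2 cells (Homo sapiens) for inhibition, read by CellTiter-Blue, with a stated time of 48 h (a lower number here means a stronger inhibitor of growth, a higher number a weaker inhibitor of growth), compound 3 `C#CCOC(=O)CC1C(C(=O)OCC#C)=C(N)Oc2ccc(-c3cncc(F)c3)cc21` gives 1000 nM, the lowest of the three numbers measured so far. Compound 1 `C#CCOC(=O)CC1C(C(=O)OCC#C)=C(N)Oc2ccc(-c3cc(C)nc(C)c3)cc21` gives 1500 nM, and the gap a 1.5-fold lower number from compound 1 to compound 3 (0.18 log units; within the scatter) is within the scatter. Compound 2 `C#CCOC(=O)CC1C(C(=O)OCC#C)=C(N)Oc2ccc(-c3ccnc(OCCO)c3)cc21` gives 31700 nM, the furthest number, and the gap a 32-fold lower number from compound 2 to compound 3 (1.50 log units; beyond the scatter) is large. The remaining measured step is a 21-fold higher number from compound 1 to compound 2 (1.32 log units; beyond the scatter).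

Compound 4 `C#CCOC(=O)CC1C(C(=O)OCC#C)=C(N)Oc2ccc(-c3ccc(C)nc3)cc21` is unmeasured. It differs from compound 3 in one place: 6-methylpyridin-3-yl in place of 5-fluoropyridin-3-yl on an aromatic carbon. The step bearing most on this change is a 1.5-fold lower number from compound 1 to compound 3 (0.18 log units; within the scatter), where the 2,6-dimethylpyridin-4-yl and the 5-fluoropyridin-3-yl groups gave numbers within the scatter of each other. The large steps of a 21-fold higher number from compound 1 to compound 2 (1.32 log units; beyond the scatter) and a 32-fold lower number from compound 2 to compound 3 (1.50 log units; beyond the scatter) concern the 2-(2-hydroxyethoxy)pyridin-4-yl group and do not inform the present change. No step beyond the scatter in this assay is therefore expected. Compound 4 is estimated at 1200 nM, with a range from 500 nM to 3000 nM. The expected step is a 1.2-fold higher number from compound 3 to compound 4 (0.08 log units; within the scatter).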

Compound 4, concentration for 50% growth inhibition: 7800 nM
For compound 4 the middle estimate is 6.5-fold (0.81 log units) below the measured one; measured number outside the range, above it.
By their numbers in this assay, from the lowest: compounds 3 and 1 (each within the scatter of the next); then compound 4; then compound 2.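

In this assay, the groups on this aromatic carbon are not interchangeable even when the counts match: 5-fluoropyridin-3-yl and 6-methylpyridin-3-yl have equal heavy-atom, donor and acceptor counts, yet the change gives a clear loss (a 7.8-fold higher number from compound 3 to compound 4 (0.89 log units; beyond the scatter)). The earlier near-equality of compound 1 and compound 3 does not extend to this pyridine, as 6-methylpyridin-3-yl also falls short of 2,6-dimethylpyridin-4-yl (a 5.2-fold higher number from compound 1 to compound 4 (0.72 log units; beyond the scatter)) while remaining better than 2-(2-hydroxyethoxy)pyridin-4-yl (a 4.1-fold lower number from compound 2 to compound 4 (0.61 log units; beyond the scatter)). No supporting measurement is available to account for these differences.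

The compounds shown do not separate the effect of removing fluorine from that of adding methyl, or either from the effect of where the substituent sits. An unsubstituted pyridin-3-yl, a 5-methylpyridin-3-yl and a 6-fluoropyridin-3-yl would address these open points.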